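This account rests on a few compounds, and the source may have more. Where it says the series, first, only, none or still open, it means among the compounds named here.

Working notes on the series, read in an ADME assay on microsomes from liver (Homo sapiens) for metabolic stability, with a stated time of 10 min; a higher number here means that more of the compound is left, a lower number that less of the compound is left. Compound 1 `CC(=O)N1CC[C@@H](C(=O)N2CC[C@](c3ccc(C(OCc4c(F)cccc4F)(C(F)(F)F)C(F)(F)F)cc3)(S(=O)(=O)c3ccc(F)cc3)C2)C1` gives 9%, compound 2 `O=C(O)C1CCN(C(=O)N2CC[C@](c3ccc(C(OCc4c(F)cccc4F)(C(F)(F)F)C(F)(F)F)cc3)(S(=O)(=O)c3ccc(F)cc3)C2)CC1` gives 72%, and compound 3 `O=C(O)[C@H]1CC[C@H](C(=O)N2CC[C@](c3ccc(C(OCc4ccccc4OC(F)(F)F)(C(F)(F)F)C(F)(F)F)cc3)(S(=O)(=O)c3ccc(F)cc3)C2)CC1` gives 93%, the highest of the three numbers and beyond the scatter from both others.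

Compound 4 `Cc1cccc(F)c1COC(c1ccc([C@]2(S(=O)(=O)c3ccc(F)cc3)CCN(C(=O)[C@H]3CC[C@H](C(=O)O)CC3)C2)cc1)(C(F)(F)F)C(F)(F)F` is compound 3 with one change: 2-fluoro-6-methylphenyl in place of 2-(trifluoromethoxy)phenyl on a saturated chain carbon bound to an oxygen on a saturated carbon. Cut one bond further out, this reads 2-(trifluoromethoxy)benzyl to 2-fluoro-6-methylbenzyl.

Within the data shown here, the only measured step, a number 63 percentage points higher from compound 1 to compound 2 (beyond the scatter), is large but lies on a carbonyl carbon, not at this place, so it gives no size for the present change. Among the measured compounds shown here, no measured step isolates this place. Compound 2 at 72% and compound 3 at 93% differ here and elsewhere, yet both stay well clear of compound 1 at 9%.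

A small downward movement is therefore expected, with the estimated step being a number 9 percentage points lower from compound 3 to compound 4 (within the scatter). The estimate for compound 4 is 84%, with an expected range from 65% to 97%.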

Compound 4, percent of the compound remaining: 79%
Compound 4: the middle estimate sits 5 percentage points above what was measured; low and high end bracket the measured number.
By their numbers in this assay, from the lowest: compound 1; then compounds 2 and 4 (each within the scatter of the next); then compound 3.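

In this assay, the place on a saturated chain carbon bound to an oxygen on a saturated carbon now has a measured size: 2-fluoro-6-methylphenyl in place of 2-(trifluoromethoxy)phenyl gives a number 14 percentage points lower from compound 3 to compound 4 (beyond the scatter), so this place is not silent to a change of aryl group. The change is modest, and compound 4 still reads 79% with the carboxylic acid side of the molecule unchanged. Nothing at hand accounts for the step, which comes with a smaller group of fewer heavy atoms and with the loss of the single hydrogen-bond acceptor.

Among these compounds, with only one pair at this place, the separate contributions of the fluorine, the methyl and the trifluoromethoxy group stay unresolved. As far as these compounds go, a plain phenyl or a phenyl carrying an amine remains open here, as does whether the step keeps its size with the 4-carboxypiperidin-1-yl group on the carbonyl carbon.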